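The source may hold more compounds than are shown below. What is called first, only, known or untested is meant among the compounds shown, and "the series" means these compounds.

Measured so far in an assay on isolated protein for inhibition of Amine oxidase [flavin-containing] B (Homo sapiens); on this read-out higher numbers stand for weaker inhibition and lower numbers for stronger inhibition:
compound 1 `C#CCNC1CCc2c(SCc3cccc(F)c3)cccc21`: 1480 nM
compound 2 `C#CCNC1CCc2c(SCCc3ccc(C)cc3)cccc21`: 25800 nM
compound 3 `C#CCNC1CCc2c(SCc3ccc(C(F)(F)F)cc3)cccc21`: 9680 nM

Compound 1 carries the lowest number of the three in this assay; its gaps to compound 3 and to compound 2 both lie beyond the usual scatter, so within this small set compound 1 is the strongest inhibitor. The step of interest leads from compound 1 to the unmeasured compound 4 `C#CCNC1CCc2c(SCc3cccc(C(F)(F)F)c3)cccc21`. The change is trifluoromethyl in place of fluoro on an aromatic carbon; the rest of the shared core, including the propargylamine and the thioether link, stays the same.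

Going by the values given here, no pair of measured compounds differing in only one place exists here, so the size of this step has no direct precedent. Among the compounds with values here, the only pointer is that compound 3 also carries a trifluoromethyl on its aromatic ring and gives 9680 nM, a weaker figure than compound 1 shows. For compound 4 a moderate loss is therefore expected, a step of a 2.4-fold higher number from compound 1 to compound 4 (0.37 log units; beyond the scatter) that lies beyond the scatter. This expected loss is taken to be smaller than the gap that separates compound 1 from compound 3. The estimate for compound 4 in this assay is 3500 nM, with a plausible range from 1200 nM to 10000 nM.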

Compound 4, half-maximal inhibitory concentration: 4.7 nM
The estimate for compound 4 lay 740-fold (2.87 log units) above the measured number; measured number outside the range, below it.
By their numbers in this assay, from the lowest: compound 4; then compound 1; then compound 3; then compound 2.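

In this assay, trifluoromethyl in place of fluoro on this aromatic carbon, meta to a large group, gives a 310-fold lower number from compound 1 to compound 4 (2.50 log units; beyond the scatter), so this position tolerates the larger group and responds strongly to the change. Compound 3 also carries trifluoromethyl, on another carbon of its aromatic ring, and gives 9680 nM, whereas compound 4 gives 4.7 nM; in these two compounds, the presence of the group does not by itself set the number, and its place on the ring matters. No available measurement explains the size of this step.

From the compounds shown here alone, it remains open whether a chloro, methoxy or nitrile group on the same carbon would keep compound 4's strength in this assay. Also open, going by these compounds, is how the trifluoromethyl at this position would fare with a longer chain in the thioether link.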